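A few compounds are considered here, and "the series" means these few. Any claim that something is new, unique, unknown or untested is made for them only; others in the source may bear on it.

Measured in an ADME assay on microsomes from liver (Homo sapiens) for metabolic stability, read by LC-MS, using NADPH, with a stated time of 30 min, tested at 1 uM; on this read-out lower numbers stand for slow clearance and higher numbers for fast clearance:
- compound 1 `COc1cc2c(cn1)Oc1ccc(NC(=O)c3ccc(Cl)cn3)cc1[C@@]21COC(N)=N1`: < 14 mL.min-1.g-1
- compound 2 `CC1(C#Cc2cncc(-c3ccc4c(c3)[C@@]3(COC(N)=N3)c3cc(C5=CCOCC5)ncc3O4)c2)COC1`: 420 mL.min-1.g-1

Compound 1 stands at the limit of < 14 mL.min-1.g-1 in this assay, at which 1 of the 2 values shown sits, so its reading is a limit and not a number. Compound 2 gives a true number, 420 mL.min-1.g-1, far up the scale.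

Compound 3 `NC1=N[C@@]2(CO1)c1cc(NC(=O)c3ccc(Cl)cn3)ccc1Oc1cnc(Cl)cc12` alters compound 1 in a single place: chloro in place of methoxy on an aromatic carbon. This puts chloro in place of methoxy on an aromatic carbon, next to the ring nitrogen. Going by the values given here, no measured pair here shows what this swap does, so no step beyond the usual scatter is expected in this assay, in either direction. That expectation rests on compound 1, whose < 14 mL.min-1.g-1 is a limit. The estimated step is a number no lower from compound 1 to compound 3 (the limit leaves the size open). For compound 3 the estimated value is 14 mL.min-1.g-1, with an expected range of 7 mL.min-1.g-1 to 35 mL.min-1.g-1.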

Compound 3, intrinsic clearance in microsomes: 37 mL.min-1.g-1
Beside the measured number, compound 3's estimate is 2.6-fold (0.42 log units) below it, outside the stated range (above it).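

In this assay, the place next to the ring nitrogen proves sensitive to what it carries: chloro in place of methoxy gives an at least 2.6-fold higher number from compound 1 to compound 3 (0.42 log units; beyond the scatter), a step beyond the scatter. Going by these compounds alone, the earlier compounds differed in more than one place, so this is the first single change that can be read on its own. The true size of the step stays open, because the reading for compound 1 is a limit and not a number: the limit of < 14 mL.min-1.g-1 in this assay, at which 1 of the 3 values shown sits.

The compounds shown do not tell whether the higher number comes from losing methoxy or from gaining chloro, and nothing here explains the change. A methyl, an amine or a nitrile at the same place could show whether other groups also raise the number, and whether any keep it as low as methoxy does.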